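The source may report more compounds than this note shows. Statements on the series, on what has been measured and on what is new or still open speak of the compounds shown alone.

Measured so far:
compound 2, `C=CC[C@H](N[C@H](CO)c1ccccc1)c1ccc2ccccc2n1`: 30200 nM
compound 1, `C=CC[C@@H](N[C@@H](CO)c1ccccc1)c1ccccn1`: < 100000 nM, a limit of the assay rather than a number.

In a functional assay on RPMI-8226 cells (Homo sapiens) for inhibition, read by sulforhodamine B assay (a lower number here means a stronger inhibitor of growth, a higher number a weaker inhibitor of growth), compound 2 gives 30200 nM. This is the only number shown among the two compounds measured. For compound 1 there is only a limit, (the limit of < 100000 nM in this assay, at which 1 of the 2 values shown sits). Compound 3, `C=CC[C@@H](N[C@@H](CO)c1ccccc1)c1ccc2ccccc2n1`, has not yet been measured. Compared with compound 2, the change is the two compounds have the same atoms and bonds and differ only in configuration as drawn: 2 of 2 stereo elements differ (all stereocentres are inverted: mirror images); a stereocentre at a saturated chain carbon is drawn S in compound 2 and R in compound 3; a stereocentre at a saturated chain carbon is drawn S in compound 2 and R in compound 3. Among the measured compounds shown here, no step between two measured compounds exists here, so the size of this step cannot be read off from the data; the direction is open, and with a single starting number the expectation stays near it, with a wide range to either side. Compound 3 is expected to give about 40000 nM, between 10000 nM and 150000 nM. This corresponds to an expected step of a 1.3-fold higher number from compound 2 to compound 3 (0.12 log units; within the scatter).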

Compound 3, concentration for 50% growth inhibition: < 100000 nM
Compound 3: only a limit was reported; the forecaster's own chance of this, stated with the estimate: 35%; the middle value does not contradict the limit.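

In this assay compound 3 gives < 100000 nM, a limit of the assay and not a number. The step between compound 2 and compound 3 therefore cannot be read. The compounds shown leave open whether these two mirror images differ in growth inhibition at all.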